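Trimming an amide side chain on a bis-benzylidene piperidone

The source may hold more compounds than are shown below. What is called first, only, known or untested is meant among the compounds shown, and "the series" means these compounds.

Measured so far:
- compound 1 `COc1ccc(/C=C2\CN(C)C/C(=C\c3ccc(OC)c(OC)c3)C2=O)cc1OC`: in a functional assay on A549 cells (Homo sapiens) for cytotoxicity, read by MTT assay, with a stated time of 72 h (on this read-out lower numbers stand for stronger inhibition and higher numbers for weaker inhibition), compound 1 gives 1300 nM
- compound 2 `CCN1C/C(=C\c2ccc(OC)c(OC)c2)C(=O)/C(=C/c2ccc(OC)c(OC)c2)C1`: in this assay compound 2 gives 3600 nM
- compound 3 `COc1cc(/C=C2\CN(C(=O)C(C)C)C/C(=C\c3cc(OC)c(OC)c(OC)c3)C2=O)cc(OC)c1OC`: in this assay compound 3 gives 800 nM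

All three share a piperidone core carrying two benzylidene arms; they differ in the group on the ring nitrogen and in how many methoxy groups dress each arm. Between compound 2 and compound 1 the only change is hydrogen in place of methyl on a saturated chain carbon bound to an amine nitrogen in a ring, and that step gave a 2.8-fold lower number from compound 2 to compound 1 (0.44 log units; beyond the scatter). How the core of compound 3 differs from that of compound 2 is not broken down here; compound 3 stands with the lowest number of the three, within the scatter of compound 1 and beyond it from compound 2.

Compound 4 `CCC(=O)N1C/C(=C\c2cc(OC)c(OC)c(OC)c2)C(=O)/C(=C/c2cc(OC)c(OC)c(OC)c2)C1` has not yet been measured. It differs from compound 3 by hydrogen in place of methyl on a saturated chain carbon bound to a carbonyl carbon and a saturated chain carbon. Going by the values given here, this is the same kind of change as the one from compound 2 to compound 1, but not the same: there the hydrogen entered on a saturated chain carbon bound to an amine nitrogen in a ring, here on a saturated chain carbon bound to a carbonyl carbon and a saturated chain carbon. Among the compounds with values here, only one earlier example of this kind of step exists, and it sits in a different surrounding, so the expectation rests on it loosely. In this assay compound 4 is expected to show a step of about a 1.1-fold lower number from compound 3 to compound 4 (0.06 log units; within the scatter), smaller than the earlier one and likely within the scatter, given that compound 3 already gives 800 nM. The estimate for compound 4 is 700 nM, spanning 300 nM to 1800 nM.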

Compound 4, half-maximal inhibitory concentration: 800 nM
Estimate against measurement, compound 4: 1.1-fold (0.06 log units) below; low and high end bracket the measured number.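

In this assay, putting hydrogen in place of methyl on a saturated chain carbon bound to a carbonyl carbon and a saturated chain carbon, which turns isopropylcarbonyl into propanoyl, gave no change at the digits printed from compound 3 to compound 4 (within the scatter). Set beside the earlier example, the change did not carry over with the same size from one core to the other: the same change on two cores in this assay, a 2.8-fold lower number (0.44 log units; beyond the scatter) from compound 2 to compound 1 and no change at the digits printed (within the scatter) from compound 3 to compound 4, 2.8-fold (0.44 log units) apart, beyond the scatter of two such steps. These two steps do not show which difference between the cores sets them apart, whether the carbonyl attached to the ring nitrogen or the additional methoxy groups on each arm, and they give no rule for what the same change would do on a third core.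

The compounds shown leave open how the number responds when the group on the ring nitrogen moves further from propanoyl, for example to acetyl, to a longer chain such as butanoyl, or to a chain ending in an amine or a carboxylic acid. On these data alone, it also remains open whether going from isopropylcarbonyl to propanoyl would leave the number as unchanged on arms with the methoxy pattern of compound 1.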